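A Pyridine Swap on a Weakly Active Amide Pair

The compounds below may be only part of what the source reports. "The series", "measured", "known", "first", "only" and "open" are said of these compounds alone.

Compound 1 `C[C@H](NC(=O)c1cccc(-c2ccc(NC(=O)C(C)(C)C)nc2)c1)C(=O)Nc1ccc(Cl)c(C(F)(F)F)c1` gives 18400 nM in a functional assay on K562 cells (Homo sapiens) for inhibition, read by MTT assay, with a stated time of 48 h; a lower number here means a stronger inhibitor, a higher number a weaker inhibitor.
Compound 2 `Nc1ccc(-c2cccc(C(=O)N[C@H]3CN[C@@H](C(=O)Nc4ccc(Cl)c(C(F)(F)F)c4)C3)c2)cn1` gives 20000 nM in this assay.

Compound 2 holds the highest of the two numbers, yet compound 1 lies so near that the two are not separable within the scatter; neither can be called weaker or stronger. Compound 3 `O=C(NC1CC1)c1cncc(-c2cccc(C(=O)N[C@H]3CN[C@@H](C(=O)Nc4ccc(Cl)c(C(F)(F)F)c4)C3)c2)c1` is not yet measured. It differs from compound 2 in one place: 5-(cyclopropylcarbamoyl)pyridin-3-yl in place of 6-aminopyridin-3-yl on an aromatic carbon. The group that leaves and the group that enters each carry one hydrogen-bond donor and two hydrogen-bond acceptors, though the entering group is larger and brings a cyclopropyl ring and an amide. The two measured compounds already carry different groups at this aromatic carbon and still give nearly the same number, so no direction is suggested. A step within the scatter is expected for a 1.3-fold lower number from compound 2 to compound 3 (0.12 log units; within the scatter). Compound 3 is therefore estimated at 15000 nM, with a plausible range from 4000 nM to 50000 nM.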

Compound 3, half-maximal inhibitory concentration: 27300 nM
Compound 3: the middle estimate sits 1.8-fold (0.26 log units) below what was measured, within the range that was stated.
By their numbers in this assay, from the lowest: compounds 1, 2 and 3 (each within the scatter of the next).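

Placing the larger 5-(cyclopropylcarbamoyl)pyridin-3-yl in place of 6-aminopyridin-3-yl on this aromatic carbon gives a 1.4-fold higher number from compound 2 to compound 3 (0.14 log units; within the scatter) in this assay, so the two compounds cannot be told apart. This direct comparison at one position shows that two groups of clearly different size, one of them carrying a cyclopropyl ring and an amide, can give numbers within the scatter of each other. Nothing measured here bears on what lies behind this result.

Going by these compounds, whether a group without a pyridine ring, such as a plain phenyl ring or a carboxylic acid, would give a number clearly apart from these remains open. On these data alone, it is also open whether a methyl group on the amide, in place of the cyclopropyl ring, would give a number within the scatter of compound 3.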